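Carbamoyl to sulfamoyl: estimating compound 3's cytotoxicity

A few compounds are considered here, and "the series" means these few. Any claim that something is new, unique, unknown or untested is made for them only; others in the source may bear on it.

Measured in an ADME assay on LLC-MK2 cells (Macaca mulatta) for cytotoxicity, read by spectrophotometry and crystal violet staining, with a stated time of 4 days; on this read-out lower numbers stand for higher toxicity in this test and higher numbers for lower toxicity in this test:
Compound 1 `CC(C)n1ncc2c(C(=O)Nc3c(F)cccc3F)cc(-c3cccs3)nc21`: > 200000 nM (a limit of the assay)
Compound 2 `CC(C)n1ncc2c(C(=O)Nc3cc(C(N)=O)ccc3F)cc(-c3cccs3)nc21`: 25000 nM

For the measured compounds named here, compound 2 holds the only actual number in this assay so far, 25000 nM. Compound 1 gives only a limit of the assay, > 200000 nM. Going by the values given here, the one measured step puts 5-carbamoyl-2-fluorophenyl in place of 2,6-difluorophenyl on an amide-type nitrogen, and it is an at least 8.0-fold lower number from compound 1 to compound 2 (0.90 log units; beyond the scatter). Its size is a bound and not an exact distance.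

Compound 3 `CC(C)n1ncc2c(C(=O)Nc3cc(S(N)(=O)=O)ccc3F)cc(-c3cccs3)nc21` differs from compound 2 in a single group, with sulfamoyl in place of carbamoyl on an aromatic carbon. Among the compounds with values here, no measured step makes this exchange, so the step above bears on it only loosely, as the step that brought in the carbamoyl now leaving. The expectation therefore rests on compound 2 at 25000 nM, and no shift beyond the scatter is expected in this assay. The expected change is a 1.2-fold higher number from compound 2 to compound 3 (0.08 log units; within the scatter). For compound 3 the estimated value is 30000 nM, with an expected range from 10000 nM to 90000 nM.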

Compound 3, half-maximal cytotoxic concentration: 25000 nM
Beside the measured number, compound 3's estimate is 1.2-fold (0.08 log units) above it; the range from low to high includes it.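

In this assay, the exchange of carbamoyl for sulfamoyl on this aromatic carbon, para to a fluoro group, comes to no change at the digits printed from compound 2 to compound 3 (within the scatter). For the compounds shown here, until now, compound 2 was the only compound with a group at this place and an actual number, so the earlier at least 8.0-fold lower number from compound 1 to compound 2 (0.90 log units; beyond the scatter) could be read only through carbamoyl. Going by these compounds alone, with a second group reading the same, the lower number is no longer tied to carbamoyl alone, although these two groups are the only evidence for that. The size of the earlier step remains a bound, since compound 1 stands at a limit of the assay: the limit of > 200000 nM in this assay, at which 1 of the 3 values shown sits.

The compounds shown leave open whether the number at this aromatic carbon would hold with a carboxylic acid, an amine or a methylsulfonyl group in place of sulfamoyl. They also leave open how much the fluoro group contributes, as a chloro group or a plain hydrogen at its place would be needed to judge whether the reading depends on it.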